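Cyclohexyl for 2-Methoxyphenoxy: Expected Cytotoxicity of Compound 3

The source may hold more compounds than are shown below. What is called first, only, known or untested is meant among the compounds shown, and "the series" means these compounds.

Two measured compounds share a core and differ only in one group on an aromatic carbon. Compound 1 `FC(F)(F)c1ccc(-c2ccc3c(NCCCNCc4ccco4)ccnc3c2)cc1` carries 4-(trifluoromethyl)phenyl there, and in an ADME assay on HepG2 cells (Homo sapiens) for cytotoxicity, read by luminescence, CellTiter-Glo and ATP content, with a stated time of 72 h (a lower number here means that less compound is needed, a higher number that more compound is needed for the effect), compound 1 gives 3470 nM. Compound 2 `COc1ccccc1Oc1ccc2c(NCCCNCc3ccco3)ccnc2c1` carries 2-methoxyphenoxy at that place, and in this assay compound 2 gives 6500 nM. Among the measured compounds shown here, the only measured step is a 1.9-fold higher number from compound 1 to compound 2 (0.27 log units; within the scatter), so compound 2 stands at the higher of the two numbers, with compound 1 as its nearest neighbour, and the two are not separated beyond the scatter.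

Compound 3 `c1coc(CNCCCNc2ccnc3cc(C4CCCCC4)ccc23)c1` has not yet been measured. cyclohexyl in place of 2-methoxyphenoxy on an aromatic carbon The change sits at the same aromatic carbon that was varied between compound 1 and compound 2, and that single step, which stayed within the scatter, is the only one bearing on it. On that basis no shift beyond the scatter is expected in this assay, and compound 3 is expected at 4500 nM, within 1500 nM to 14000 nM. Expressed as a step, the estimate means a 1.4-fold lower number from compound 2 to compound 3 (0.16 log units; within the scatter).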

Compound 3, half-maximal effective concentration: 4760 nM
Beside the measured number, compound 3's estimate is 1.1-fold (0.02 log units) below it, within the range that was stated.
By their numbers in this assay, from the lowest: compounds 1, 3 and 2 (each within the scatter of the next).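

Compound 3 is the first of these compounds to carry a non-aromatic ring at this aromatic carbon, a cyclohexyl with 0 hydrogen-bond acceptors, where 2-methoxyphenoxy brought one six-membered aromatic ring and 2 hydrogen-bond acceptors. In this assay that exchange amounts to a 1.4-fold lower number from compound 2 to compound 3 (0.14 log units; within the scatter), and the exchange for 4-(trifluoromethyl)phenyl amounts to a 1.4-fold higher number from compound 1 to compound 3 (0.14 log units; within the scatter), so neither separates compound 3 from the compound it is compared with. Among the compounds shown here, the earlier pair showed only that two groups with aromatic rings could not be told apart here; the three compounds now show that neither an aromatic ring in the group nor its hydrogen-bond acceptors are needed for a number within the scatter of the others, and none of the three goes against this. Nothing at hand bears on why the numbers stay so close. Going by these compounds, whether an amine or a carboxylic acid at this aromatic carbon would give a step beyond the scatter remains open. Also open, on these data alone, is what a longer chain in place of the side chain would do in this assay, as that part is the same in all three compounds.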